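A few compounds are considered here, and "the series" means these few. Any claim that something is new, unique, unknown or untested is made for them only; others in the source may bear on it.

In a functional assay, read by spectrophotometry, with a stated time of 2 h (a higher number here means a weaker inhibitor, a lower number a stronger inhibitor), compound 1 `COC(=O)C1=C(C)NC(=O)NC1c1ccc(OC)cc1` gives 31.7 ug/mL, compound 2 `COC(=O)C1=C(C)NC(=O)NC1c1ccc(O)cc1` gives 3.14 ug/mL, and compound 3 `COC(=O)C1=C(C)NC(=O)NC1c1ccccc1` gives 28.4 ug/mL. Compound 2 has the lowest number of the three and is the strongest inhibitor among them. Hydrogen in place of methyl on an oxygen on the aromatic ring gives a 10-fold lower number from compound 1 to compound 2 (1.00 log units; beyond the scatter). Hydrogen in place of hydroxy on an aromatic carbon gives a 9.0-fold higher number from compound 2 to compound 3 (0.96 log units; beyond the scatter). Hydrogen in place of methoxy on an aromatic carbon gives a 1.1-fold lower number from compound 1 to compound 3 (0.05 log units; within the scatter).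

Compound 4 `CCOC(=O)C1=C(C)NC(=O)NC1c1ccc(O)cc1` differs from compound 2 elsewhere: methyl in place of hydrogen on a saturated chain carbon bound to an oxygen next to a carbonyl group. This is methyl in place of hydrogen on a saturated chain carbon bound to an oxygen next to a carbonyl group, or methoxycarbonyl to ethoxycarbonyl. From the compounds shown here alone, all three measured steps lie on the aromatic ring, so none tests this place, and the size of a change there is unknown from these data. Both steps beyond the scatter involve the hydroxy, which compound 4 retains, so the anchor for the expectation is compound 2 at 3.14 ug/mL. No change beyond the scatter is expected in this assay, and the estimated step is a 1.1-fold higher number from compound 2 to compound 4 (0.05 log units; within the scatter). For compound 4 the estimate is 3.5 ug/mL, with an expected range of 1.4 ug/mL to 9 ug/mL.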

Compound 4, half-maximal inhibitory concentration: 2.71 ug/mL
For compound 4 the middle estimate is 1.3-fold (0.11 log units) above the measured one; the range from low to high includes it.
By their numbers in this assay, from the lowest: compounds 4 and 2 (each within the scatter of the next); then compounds 3 and 1 (each within the scatter of the next).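

In this assay, within the data shown here, the change from methoxycarbonyl to ethoxycarbonyl gives a 1.2-fold lower number from compound 2 to compound 4 (0.06 log units; within the scatter), the first reading at this position away from the aromatic ring. One added methyl on the saturated chain carbon bound to an oxygen next to a carbonyl group therefore leaves compound 2 and compound 4 indistinguishable, so this place accepts methyl in place of hydrogen with the hydroxy retained, unlike the changes at the hydroxy on the aromatic ring, where the steps lie beyond the scatter. No measurement at hand explains why this step stays within the scatter.

The compounds shown leave open whether this position stays as undemanding with a longer chain such as butoxycarbonyl, a branched group such as isopropoxycarbonyl, or a carboxylic acid or primary amide in place of the methoxycarbonyl. They also leave open whether ethoxycarbonyl reads the same when the hydroxy on the aromatic ring is replaced by methoxy or hydrogen, since this change has been read only with the hydroxy present.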